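This account rests on a few compounds, and the source may have more. Where it says the series, first, only, none or still open, it means among the compounds named here.

Compound 1 `CC(C(=O)Nc1cccc(Cl)c1)N1C(=O)CCC1=O` gives 105 mg/kg in a functional assay on the whole organism (strain Swiss) with Mus musculus as the target, in the maximal electroshock model; a higher number here means that more compound is needed for the effect, a lower number that less compound is needed.
Compound 2 `CCC(C(=O)Nc1cccc(Cl)c1)N1C(=O)CCC1=O` gives only a limit, > 130 mg/kg.

For the measured compounds named here, compound 1 thus stands as the single numeric value in this assay; the other entry is the limit of > 130 mg/kg in this assay, at which 1 of the 2 values shown sits. Compound 3 `CC1CC(=O)N(C(C)C(=O)Nc2cccc(Cl)c2)C1=O` differs from compound 1 by methyl in place of hydrogen on a saturated ring carbon. Going by the values given here, the one measured step that bears on this is an at least 1.2-fold higher number from compound 1 to compound 2 (0.09 log units; that floor lies within the scatter), a methyl entering on the chain rather than on the ring; it points to a higher number, though its floor lies within the scatter. The expected step is therefore a 1.2-fold higher number from compound 1 to compound 3 (0.09 log units; within the scatter), a modest rise that may not exceed the scatter. Compound 3 is estimated at 130 mg/kg, with a range from 70 mg/kg to 260 mg/kg.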

Compound 3, dose for half-maximal effect: 80.6 mg/kg
Estimate against measurement, compound 3: 1.6-fold (0.21 log units) above; low and high end bracket the measured number.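

In this assay methyl in place of hydrogen on a saturated ring carbon, two ring bonds from the ring nitrogen, gives a 1.3-fold lower number from compound 1 to compound 3 (0.11 log units; within the scatter) and so shows that this ring position can carry a methyl with the number held within the scatter. For the compounds shown here, this is the first numeric reading of an added methyl. Compound 2, with its methyl on the chain, is recorded only as a limit, so the two methyl positions cannot be ranked: the limit of > 130 mg/kg in this assay, at which 1 of the 3 values shown sits.

As far as these compounds go, whether a longer chain such as ethyl, or a phenyl ring, would be accommodated at this ring carbon remains open. So does the effect of a second methyl on the same carbon.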